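The source may report more compounds than this note shows. Statements on the series, on what has been measured and on what is new or still open speak of the compounds shown alone.

Compound 1, whose structure is `CNC(=O)Nc1ccc(-c2nc(N3CC4CCC(C3)O4)c3sccc3n2)cc1`, carries a methylurea on the aryl group attached to the shared core. In a functional assay on LNCaP cells (Homo sapiens) for cytotoxicity (on this read-out higher numbers stand for weaker inhibition and lower numbers for stronger inhibition), compound 1 gives 85 nM, the lowest of the two numbers recorded so far. Within the data shown here, the only companion, compound 2 with structure `c1cc2cc(-c3nc(N4CC5CCC(C4)O5)c4sccc4n3)ccc2[nH]1`, gives in this assay a value of 1350 nM, a considerably higher number that lies beyond the usual scatter; the two compounds differ in more than one place, so no single step connects them, and the pair shows only that compound 1 is the stronger inhibitor of the two.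

Compound 3, of structure `O=C(Nc1ccc(-c2nc(N3CC4CCC(C3)O4)c3sccc3n2)cc1)Nc1cccnc1`, keeps the urea and the core of compound 1 and alters the urea alone: pyridin-3-yl in place of methyl on an amide-type nitrogen. Among the measured compounds shown here, nothing measured so far bears on this change, since no pair differing in exactly one place has been recorded. It is expected that the step from compound 1 to compound 3 in this assay, namely a 1.4-fold lower number from compound 1 to compound 3 (0.15 log units; within the scatter), is small, toward a somewhat lower number, and not clearly beyond the scatter. For compound 3 the value in this assay is estimated at 60 nM, with a plausible range from 20 nM to 250 nM.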

Compound 3, half-maximal inhibitory concentration: 27 nM
Compound 3: the middle estimate sits 2.2-fold (0.35 log units) above what was measured; the measured number falls inside the stated range.
By their numbers in this assay, from the lowest: compound 3; then compound 1; then compound 2.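

Among these compounds, this is the first pair that differs in one place only, so the group on the urea can now be read on its own: in this assay, pyridin-3-yl in place of methyl on an amide-type nitrogen gives a 3.1-fold lower number from compound 1 to compound 3 (0.50 log units; beyond the scatter). The step is modest but beyond the usual scatter, and it shows that this nitrogen accepts a six-membered aromatic ring of six heavy atoms in place of a single carbon with no loss on this read-out, the number in fact going down. No measurement at hand says what in the entering group accounts for this step.

With one aromatic group at this nitrogen, the compounds shown leave open whether the ring itself or its ring nitrogen goes with the lower number; phenyl and pyridin-4-yl on the same urea would separate these, and an ethyl or a longer chain would show how the number moves without any ring. Going by these compounds, how the urea compares with the indole-bearing aryl group of compound 2 also stays open, since that compound differs from the others in more than one place.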